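This account rests on a few compounds, and the source may have more. Where it says the series, first, only, none or still open, it means among the compounds named here.

Measured so far:
compound 1, `O=C1/C(=C/c2ccc(Cl)cc2)CCC/C1=C\c1ccccc1[N+](=O)[O-]`: 6100 nM
compound 2, `CN(C)c1ccc(/C=C2\CCC/C(=C\c3ccccc3[N+](=O)[O-])C2=O)cc1`: > 400000 nM
compound 3, `O=C1/C(=C/c2ccc(Cl)cc2)CCC/C1=C\c1ccc([N+](=O)[O-])cc1`: 2700 nM

The series was tested in a functional assay on HSC-4 cells (Homo sapiens) for cytotoxicity, with a stated time of 24 h; on this read-out higher numbers stand for lower toxicity in this test and lower numbers for higher toxicity in this test. Compound 1, `O=C1/C(=C/c2ccc(Cl)cc2)CCC/C1=C\c1ccccc1[N+](=O)[O-]`, gives 6100 nM in this assay. Compound 2, `CN(C)c1ccc(/C=C2\CCC/C(=C\c3ccccc3[N+](=O)[O-])C2=O)cc1`, reaches only a limit of the assay there, > 400000 nM, and no number. Compound 3, `O=C1/C(=C/c2ccc(Cl)cc2)CCC/C1=C\c1ccc([N+](=O)[O-])cc1`, gives 2700 nM in this assay, the lowest of the two numbers seen, with compound 1 nearest to it.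

Going by the values given here, the one measured step is the change (dimethylamino in place of chloro on an aromatic carbon), which gives an at least 65-fold higher number from compound 1 to compound 2 (1.81 log units; beyond the scatter). The size of this step is bounded only from one side because of the limit of > 400000 nM in this assay, at which 1 of the 3 values shown sits.

Compound 4, `CN(C)c1ccc(/C=C2\CCC/C(=C\c3ccc([N+](=O)[O-])cc3)C2=O)cc1`, is yet to be measured. It carries the same change, (dimethylamino in place of chloro on an aromatic carbon), on the core of compound 3. The cores of compound 3 and compound 1 share the same atoms joined differently, and the difference between the two cores is not broken down here.

On the core of compound 1 this change moved the number far up. On the core of compound 3 the same change is expected to give a step of about a 93-fold higher number from compound 3 to compound 4 (1.97 log units; beyond the scatter) in this assay, resting on the step from compound 1 to compound 2. Compound 4 is therefore estimated at 250000 nM, in the range 60000 nM to 1000000 nM, with a fair chance that only a limit is reported.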

Compound 4, half-maximal cytotoxic concentration: > 400000 nM
Compound 4 was reported as a limit (the forecaster's own chance of this, stated with the estimate: 55%); middle value at least 1.6-fold (0.20 log units) away from the limit.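

In this assay, dimethylamino in place of chloro gives an at least 140-fold higher number from compound 3 to compound 4 (2.17 log units; beyond the scatter), so on the core of compound 3 the change moves the number in the same direction as it did on the core of compound 1, and the step is large on both cores. Compound 4 gives > 400000 nM, which is a limit of the assay and not a number, and compound 2 stands at the same limit. The change thus carries over between these two cores in direction, but the pair of steps does not show whether its size is the same on both: the same change on two cores in this assay, an at least 65-fold higher number (1.81 log units; beyond the scatter) from compound 1 to compound 2 and an at least 140-fold higher number (2.17 log units; beyond the scatter) from compound 3 to compound 4; the limit leaves it open whether they differ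

The step from compound 2 to compound 4, which exchanges 2-nitrophenyl for 4-nitrophenyl, cannot be read, and how far either compound lies past the limit also stays unknown: the limit of > 400000 nM in this assay, at which 2 of the 4 values shown sit. The compounds shown also leave open whether a smaller amine, such as a primary amine or a methylamino group, or a methoxy group in place of chloro would move the number as dimethylamino does, and whether a number could be read for such compounds on either core.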